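Swapping Phenyl for Isopropylsulfanyl on the Shared Core

The source may hold more compounds than are shown below. What is called first, only, known or untested is meant among the compounds shown, and "the series" means these compounds.

Compound 1 `CCc1cc(C)c(C(=O)N=C(N)N)cc1S(C)(=O)=O` and compound 2 `Cc1cc(-c2ccccc2)c(S(C)(=O)=O)cc1C(=O)N=C(N)N` share a core and differ in one group. In a functional assay for inhibition of sodium/hydrogen exchanger (Oryctolagus cuniculus) (on this read-out lower numbers stand for stronger inhibition and higher numbers for weaker inhibition), compound 1 gives 4.8 nM, while compound 2 gives 19 nM, the highest of the two numbers measured. That step, a 4.0-fold higher number from compound 1 to compound 2 (0.60 log units; beyond the scatter), is the only one recorded. Compound 3 `Cc1cc(SC(C)C)c(S(C)(=O)=O)cc1C(=O)N=C(N)N` carries isopropylsulfanyl in place of phenyl on an aromatic carbon. For the measured compounds named here, no measured step covers this exact change; the sole step shows that exchanging ethyl for phenyl weakened inhibition, and isopropylsulfanyl, which has no ring and fewer heavy atoms, may partly reverse that. The expected step is a 2.1-fold lower number from compound 2 to compound 3 (0.32 log units; beyond the scatter). The estimate for compound 3 is 9 nM, with a range from 3 nM to 30 nM.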

Compound 3, half-maximal inhibitory concentration: 12 nM
Compound 3: middle estimate off by 1.3-fold (0.12 log units), on the low side; low and high end bracket the measured number.
By their numbers in this assay, from the lowest: compound 1; then compounds 3 and 2 (each within the scatter of the next).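

In this assay, putting isopropylsulfanyl in place of phenyl gives a 1.6-fold lower number from compound 2 to compound 3 (0.20 log units; within the scatter), so this change at this position does not separate the two compounds, although the ring is gone and a sulfur has entered. Measured against ethyl, isopropylsulfanyl gives a 2.5-fold higher number from compound 1 to compound 3 (0.40 log units; beyond the scatter), which leaves compound 1 with the lowest number of the three. Nothing available explains these differences. The compounds shown leave open how an amine, a methoxy group or a longer chain would behave here, and whether any group at this position can give a lower number than ethyl.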